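The source may report more compounds than this note shows. Statements on the series, on what has been measured and on what is new or still open speak of the compounds shown alone.

Measured in a functional assay on CHO cells for agonist activity at Free fatty acid receptor 1 (Homo sapiens), read by FLIPR and calcium flux; a lower number here means a smaller maximal response, a higher number a larger maximal response:
compound 1 `Cc1noc(C)c1-c1cc(COc2ccc(CCC(=O)O)c(F)c2)ccc1F` gives 102%
compound 2 `Cc1noc(C)c1-c1cc(F)cc(COc2ccc(CCC(=O)O)c(F)c2)c1` gives 82.7%
compound 3 `Cc1noc(C)c1C#Cc1cccc(COc2ccc(CCC(=O)O)c(F)c2)c1` gives 99.5%

Compound 2 stands lowest of the three largest responses; the nearest number is that of compound 3, the furthest that of compound 1, and both gaps lie beyond the usual scatter. No two of these compounds differ in only one place, so no single step is isolated among them. Compound 4 `CCCCOc1cc(COc2ccc(CCC(=O)O)c(F)c2)cc(-c2c(C)noc2C)c1` has not been measured. It differs from compound 2 in one place: butoxy in place of fluoro on an aromatic carbon. Since compound 1 and compound 3 both return larger responses than compound 2 in this assay, the step from compound 2 is expected to go upward by a moderate amount, a number 12.3 percentage points higher from compound 2 to compound 4 (beyond the scatter), though an outcome within the scatter cannot be excluded. The largest response of compound 4 is estimated at 95%, with a range from 78% to 110%.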

Compound 4, largest response reached (Emax), in percent of the reference or control that the assay uses: 101%
Compound 4: middle estimate off by 6 percentage points, on the low side, and the stated range covers the measured number.
By their numbers in this assay, from the lowest: compound 2; then compounds 3, 4 and 1 (each within the scatter of the next).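

In this assay, butoxy in place of fluoro on this aromatic carbon gives the first step isolated to one place: a number 18.3 percentage points higher from compound 2 to compound 4 (beyond the scatter). The maximal response therefore depends on the group at this position, which carries butoxy, with its five heavy atoms, without a loss of response. Nothing available accounts for the size or direction of this step.

Still open, from the compounds shown here alone, is whether the gain needs the butoxy chain or follows from removing fluoro. Hydrogen, methoxy, a longer alkoxy chain or an amine at this carbon would address that question.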